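The source may hold more compounds than are shown below. What is called first, only, known or untested is meant among the compounds shown, and "the series" means these compounds.

Three compounds of a shared core, compound 1 `CCCS(=O)(=O)Nc1ccc(F)c(C(=O)c2n[nH]c3ncc(-c4ccc(S(=O)(=O)NC)cc4)cc23)c1F`, compound 2 `CCCS(=O)(=O)Nc1ccc(F)c(C(=O)c2n[nH]c3ncc(-c4ccc(S(=O)(=O)NC(C)=O)cc4)cc23)c1F` and compound 3 `CCCS(=O)(=O)Nc1ccc(F)c(C(=O)c2n[nH]c3ncc(-c4ccc(C(=O)O)cc4)cc23)c1F`, were measured in an assay for binding affinity to dual specificity mitogen-activated protein kinase kinase 4 (Homo sapiens), read by KINOMEscan, tested at 10 nM; a lower number here means a stronger effect, a higher number a weaker effect of the compound at the concentration tested. Compound 1 gives 14%, compound 2 gives 0.5% and compound 3 gives 0.2%. Compound 2 thus stands second highest of the three numbers, nearest to compound 3 and within the scatter of it, furthest from compound 1 and beyond the scatter. Compound 4 `CCCS(=O)(=O)Nc1ccc(F)c(C(=O)c2n[nH]c3ncc(-c4ccc(C(N)=O)cc4)cc23)c1F` is not yet measured; it differs from compound 2 by carbamoyl in place of acetylsulfamoyl on an aromatic carbon. The steps of a number 13.5 percentage points lower from compound 1 to compound 2 (beyond the scatter) and a number 13.8 percentage points lower from compound 1 to compound 3 (beyond the scatter) both lower the number after methylsulfamoyl is replaced, while a number 0.3 percentage points lower from compound 2 to compound 3 (within the scatter) shows no separation between acetylsulfamoyl and carboxy. Compound 4 is therefore expected to give 2%, between 0.1% and 12%. The step of a number 1.5 percentage points higher from compound 2 to compound 4 (within the scatter) that this estimate means is expected to lie within the scatter.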

Compound 4, a percentage reported as activity, at one concentration (the size of the read-out at that concentration, not a potency): 4%
Compound 4: the middle estimate sits 2 percentage points below what was measured; low and high end bracket the measured number.
By their numbers in this assay, from the lowest: compounds 3, 2, 4 and 1 (each within the scatter of the next, the first and the last beyond it).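

In this assay, carbamoyl does not separate from acetylsulfamoyl at this position on the aromatic ring (a number 3.5 percentage points higher from compound 2 to compound 4 (within the scatter)), and amino in place of hydroxy on the carbonyl carbon likewise gives no separation (a number 3.8 percentage points higher from compound 3 to compound 4 (within the scatter)). The step of a number 10 percentage points lower from compound 1 to compound 4 (within the scatter) also stays within the scatter, so compound 4 lies within the scatter of all three earlier compounds and blurs the division that set methylsulfamoyl apart from acetylsulfamoyl and carboxy. No evidence is available that explains these results. The compounds shown leave open how an aminomethyl group, a methyl ester or a tetrazole would read at this position.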